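Fluorophenyl placement on the spiro imidazolone core

This account rests on a few compounds, and the source may have more. Where it says the series, first, only, none or still open, it means among the compounds named here.

Three compounds of this series carry numbers in an assay on CHO cells for displacement of a labelled ligand from Glucagon receptor (Homo sapiens), read by scintillation counting, with a stated time of 60 min; on this read-out higher numbers stand for weaker inhibition and lower numbers for stronger inhibition. Compound 1 `C[C@H](c1ccc(C(=O)NCCC(=O)O)cc1)N1C(=O)C(c2ccc(F)cc2)=N[C@]12CC[C@@H](C(C)(C)C)CC2` gives 85 nM, the second highest of the three. Compound 2 `CCC[C@H](c1ccc(C(=O)NCc2nn[nH]n2)cc1)N1C(=O)C(c2cc(Cl)cc(Cl)c2)=N[C@]12CC[C@@H](C(C)(C)C)CC2` gives 55 nM, which lies within the scatter of compound 1. Compound 3 `CC(C)(C)[C@H]1CC[C@]2(CC1)N=C(c1cccc(Cl)c1)C(=O)N2Cc1ccc(C(=O)NCCC(=O)O)cc1` gives 770 nM, the highest number and well beyond the scatter from compound 1.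

Compound 4 `C[C@H](c1ccc(C(=O)NCCC(=O)O)cc1)N1C(=O)C(c2ccccc2F)=N[C@]12CC[C@@H](C(C)(C)C)CC2` has not yet been measured in this assay. It differs from compound 1 in one place: 2-fluorophenyl in place of 4-fluorophenyl on a carbon with a double bond to nitrogen. Among the measured compounds shown here, no measured pair shows this change, so the size of the step is unknown. A small step is expected, toward a somewhat higher number, possibly none beyond the scatter, as a 1.8-fold higher number from compound 1 to compound 4 (0.25 log units; within the scatter). For compound 4 the estimate is 150 nM, within 50 nM to 450 nM.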

Compound 4, half-maximal inhibitory concentration: 1100 nM
The estimate for compound 4 lay 7.3-fold (0.87 log units) below the measured number; the measured number lies above the stated range.
By their numbers in this assay, from the lowest: compounds 2 and 1 (each within the scatter of the next); then compounds 3 and 4 (each within the scatter of the next).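

In this assay the carbon with a double bond to nitrogen proves sensitive to where the fluorine sits on its phenyl group: 2-fluorophenyl in place of 4-fluorophenyl gives a 13-fold higher number from compound 1 to compound 4 (1.11 log units; beyond the scatter) even though the two groups have the same atoms. The earlier compounds shown here differ from one another in more than one place, so they could not show this. No measurement at hand accounts for the step. From the compounds shown here alone, whether an unsubstituted phenyl on this carbon would lie nearer compound 1 or compound 4 remains open. Also open, going by these compounds, is whether chlorine or methoxy in place of the fluorine of 2-fluorophenyl would give a step of similar size.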